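The source may report more compounds than this note shows. Statements on the series, on what has been measured and on what is new or still open speak of the compounds shown alone.

The measured compounds and their values:

Compound 1, `Cc1nn(C(C)(C)C)c2nc(C3CC3)c(/C=C/[C@@H](O)C[C@@H](O)CC(=O)O)c(-c3ccc(F)cc3)c12`: 72.2%
Compound 2, `Cc1nn(C(C)(C)C)c2nc(C(C)C)c(/C=C/[C@@H](O)C[C@@H](O)CC(=O)O)c(-c3ccc(F)cc3)c12`: 86%
Compound 3, `CC(C)c1nc2c(c(-c3ccccc3)nn2C)c(-c2ccc(F)cc2)c1/C=C/[C@@H](O)C[C@@H](O)CC(=O)O`: 71.1%

All three were tested in an in vivo functional assay on the whole organism for inhibition of 3-hydroxy-3-methylglutaryl-coenzyme A reductase (Rattus norvegicus), at a dose of 2 mg/kg by the oral route; on this read-out lower numbers stand for a weaker effect and higher numbers for a stronger effect at the one dose given. Compound 2 gives 86%, and compound 1 gives 72.2%. Going by the values given here, the two differ in one place, (cyclopropyl in place of isopropyl on an aromatic carbon), and the step of a number 13.8 percentage points lower from compound 2 to compound 1 (beyond the scatter) is the one direct comparison available for this change. Compound 3 gives 71.1%, a number close to that of compound 1 and further from that of compound 2. Compound 3 and compound 2 share the same change of isopropyl to cyclopropyl in prospect, but the difference between the two cores themselves is not broken down here.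

Compound 4, `Cn1nc(-c2ccccc2)c2c(-c3ccc(F)cc3)c(/C=C/[C@@H](O)C[C@@H](O)CC(=O)O)c(C3CC3)nc21`, has not yet been measured. Among the compounds with values here, it differs from compound 3 by cyclopropyl in place of isopropyl on an aromatic carbon, the same change as the one from compound 2 to compound 1, sitting in the same surroundings in both cases. If that change acts on the core of compound 3 as it did on the core of compound 2, compound 4 should read lower than compound 3 in this assay by roughly the step already seen. A step of a number 13.1 percentage points lower from compound 3 to compound 4 (beyond the scatter) is therefore expected from compound 3 to compound 4, resting on the earlier step of a number 13.8 percentage points lower from compound 2 to compound 1 (beyond the scatter) and on the value of compound 3, 71.1%. Within the data shown here, with only one precedent, the expected range for compound 4 is kept wide, from 45% to 70%. The estimate for compound 4 is 58%.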

Compound 4, a percentage reported as inhibition, in the whole organism at one dose (the size of the read-out at that dose, not a potency): 11.5%
Beside the measured number, compound 4's estimate is 46.5 percentage points above it; measured number below the stated range.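

Moved to a second core, the swap of isopropyl for cyclopropyl on the aromatic carbon gave a far larger drop in this assay than the single precedent had: a number 59.6 percentage points lower from compound 3 to compound 4 (beyond the scatter). The change lowered the reading on both cores, but the size of the drop did not carry over from one to the other: the same change on two cores in this assay, a number 13.8 percentage points lower (beyond the scatter) from compound 2 to compound 1 and a number 59.6 percentage points lower (beyond the scatter) from compound 3 to compound 4, 45.8 percentage points apart, beyond the scatter of two such steps. This shows that, in this series, a step measured on one core is a poor guide to the size of the same step on another, though two pairs cannot show how the step depends on the core, and readings at one oral dose in the whole organism are not potencies.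

The compounds shown leave open how other groups on the same aromatic carbon, such as an ethyl group or a cyclobutyl ring, would read on each core, and so whether the sharp drop is particular to cyclopropyl. It also remains open which of the several differences between the two cores sets the size of the step, since the pairs shown do not separate those differences from one another.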